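A few compounds are considered here, and "the series" means these few. Any claim that something is new, unique, unknown or untested is made for them only; others in the source may bear on it.

Measured in a functional assay on LNCaP cells (Homo sapiens) for antiproliferative activity, read by WST assay, with a stated time of 3 days; a higher number here means a weaker inhibitor, a lower number a stronger inhibitor:
- compound 1 `CCCCCCCOc1c(-c2cc(OC)c(OC)c(OC)c2)oc2ccccc2c1=O`: > 50000 nM, a limit of the assay and not a number
- compound 2 `CCN(CC)CCCCOc1c(-c2cc(OC)c(OC)c(OC)c2)oc2ccccc2c1=O`: 13500 nM
- compound 3 `CCCN(CCC)CCCCOc1c(-c2cc(OC)c(OC)c(OC)c2)oc2ccccc2c1=O`: 16800 nM

The two numeric values sit together, with a 1.2-fold higher number from compound 2 to compound 3 (0.09 log units; within the scatter). Compound 4 `CCCCCN(CCCCC)CCCOc1c(-c2cc(OC)c(OC)c(OC)c2)oc2ccccc2c1=O` differs from compound 3 by dipentylamino in place of (dipropylamino)methyl on a saturated chain carbon, three bonds along the chain from an oxygen on an aromatic ring. In words, dipentylamino stands in place of (dipropylamino)methyl.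

The bearing steps are an at least 3.7-fold lower number from compound 1 to compound 2 (0.56 log units; beyond the scatter) and an at least 2.9-fold lower number from compound 1 to compound 3 (0.47 log units; beyond the scatter), which show the gain on bringing in an amino group. The swap from diethylamino to dipropylamino gave only a 1.2-fold higher number from compound 2 to compound 3 (0.09 log units; within the scatter). Among the compounds with values here, no measured step tests dipentylamino or a change at this place, so no shift beyond the scatter is expected in this assay. The expected change is a 1.5-fold lower number from compound 3 to compound 4 (0.18 log units; within the scatter). For compound 4 the estimate is 11000 nM, with an expected range of 3500 nM to 30000 nM.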

Compound 4, half-maximal inhibitory concentration: 5100 nM
Compound 4: the middle estimate sits 2.2-fold (0.33 log units) above what was measured; the measured number falls inside the stated range.
By their numbers in this assay, from the lowest: compound 4; then compounds 2 and 3 (each within the scatter of the next). At a limit, above all of these: compound 1.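

In this assay this change, unlike the swap from diethylamino to dipropylamino, goes beyond the scatter, giving a 3.3-fold lower number from compound 3 to compound 4 (0.52 log units; beyond the scatter) and a 2.6-fold lower number from compound 2 to compound 4 (0.42 log units; beyond the scatter) in the same direction. It shortens the chain to the amine and lengthens the groups on the nitrogen together, so the two effects cannot be separated here. A further step, an at least 9.8-fold lower number from compound 1 to compound 4 (0.99 log units; beyond the scatter), starts from a limit of the assay: the limit of > 50000 nM in this assay, at which 1 of the 4 values shown sits.

Open, from the compounds shown here alone, is how dipentylamino behaves on the longer chain of compound 3 and how dipropylamino behaves on the shorter chain of compound 4. Also open, going by these compounds, is whether a cyclic amine such as piperidine or morpholine at this place keeps the gain.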